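Removing the piperazine substituent from the pyridine ring

The compounds below may be only part of what the source reports. "The series", "measured", "known", "first", "only" and "open" are said of these compounds alone.

Compound 1 `CCC(=O)NCc1cncc(N2C(=O)c3ccc(Cl)cc3C2(C)C)c1` gives 282 nM in an assay on cells for inhibition of cytochrome P450 11B2, mitochondrial (Homo sapiens), read by HTRF; a lower number here means a stronger inhibitor, a higher number a weaker inhibitor.
Compound 2 `CC1(C)c2cc(Cl)ccc2C(=O)N1c1cncc(N2CCN(S(C)(=O)=O)CC2)c1` gives 2 nM in this assay.
Compound 3 `CC(=O)N1CCN(c2cncc(N3C(=O)c4ccc(Cl)cc4C3(C)C)c2)CC1` gives 9 nM in this assay.

Compound 3 stands second among the three measured numbers. Its nearest neighbour is compound 2, which lies a 4.5-fold higher number from compound 2 to compound 3 (0.65 log units; beyond the scatter) away in the reverse direction; the furthest is compound 1, separated by a 31-fold lower number from compound 1 to compound 3 (1.50 log units; beyond the scatter). Both steps are beyond the scatter, and both concern the group on the pyridine ring two atoms from the ring nitrogen.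

Compound 4 `CC1(C)c2cc(Cl)ccc2C(=O)N1c1cccnc1` carries no substituent there at all: hydrogen in place of 4-acetylpiperazin-1-yl on an aromatic carbon. The change that bears on it is the step from compound 1 to compound 3, which showed how much a different group at this place can shift the number, and the step from compound 2 to compound 3, which showed that even the cap on the piperazine matters. Taking the group away entirely is a larger change than either. Compound 4 is therefore expected to give a higher number, estimated at 500 nM with a range of 100 nM to 3000 nM, a step of a 56-fold higher number from compound 3 to compound 4 (1.74 log units; beyond the scatter).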

Compound 4, half-maximal inhibitory concentration: 108 nM
For compound 4 the middle estimate is 4.6-fold (0.67 log units) above the measured one; measured number inside the range.
By their numbers in this assay, from the lowest: compound 2; then compound 3; then compound 4; then compound 1.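

With nothing but hydrogen on this aromatic carbon, this assay shows a 12-fold higher number from compound 3 to compound 4 (1.08 log units; beyond the scatter), so the 4-acetylpiperazin-1-yl group accounts for a large gain, yet the shared core without it still gives a measurable number in the same assay. The other comparison runs the opposite way, with a 2.6-fold lower number from compound 1 to compound 4 (0.42 log units; beyond the scatter), so (propanoylamino)methyl at this place is worse than no substituent at all, and a group here can either lower or raise the number relative to hydrogen. No measurement shown here explains either shift.

The compounds shown leave open whether the gain needs the whole piperazine ring or only an amine nitrogen attached to the aromatic ring, as a dimethylamino group or an unsubstituted piperazine would test. They also leave open how a small group such as methyl would compare with hydrogen.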